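The compounds below may be only part of what the source reports. "The series", "measured", "known", "first", "only" and "open" are said of these compounds alone.

Within the data shown here, in an ADME assay on the whole organism (Mus musculus, strain BALB/C), read by LC-MS, with a stated time of 24 h, at a dose of 1 mg/kg by the intravenous route (on this read-out higher numbers stand for higher exposure at the dose given and lower numbers for lower exposure), compound 1 `C[C@H](Nc1nc(N)nc(N)c1C#N)c1cc2ccc(F)cn2c(=O)c1-c1ccccc1` gives 665 ng.h/mL, the lowest of the two numbers measured so far. Its nearest neighbour, compound 2 `C[C@H](Nc1nc(N)nc(N)c1C#N)c1cc(=O)n2cc(F)ccc2c1-c1cc(F)cc(F)c1`, gives 903 ng.h/mL in this assay, a value that lies within the usual scatter of that of compound 1, so the two cannot be set in order. Compound 3 `Cc1c([C@H](C)Nc2nc(N)nc(N)c2C#N)c(-c2ccccc2)c(=O)n2cc(F)ccc12` has not yet been measured in this assay. It differs from compound 1 in one place: methyl in place of hydrogen on an aromatic carbon. Among the measured compounds shown here, no pair of measured compounds shows this change, so its effect in this assay is not known from the data; a step no larger than the scatter is expected, with no clear direction, and compound 1 serves as the anchor. For compound 3 the estimated exposure in this assay is 650 ng.h/mL, with a range from 250 ng.h/mL to 1700 ng.h/mL. The expected step, a 1.0-fold lower number from compound 1 to compound 3 (0.01 log units; within the scatter), is accordingly small.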

Compound 3, area under the concentration-time curve: 344 ng.h/mL
For compound 3 the middle estimate is 1.9-fold (0.28 log units) above the measured one; the measured number falls inside the stated range.
By their numbers in this assay, from the lowest: compounds 3, 1 and 2 (each within the scatter of the next, the first and the last beyond it).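

In this assay, methyl in place of hydrogen on an aromatic carbon gives a 1.9-fold lower number from compound 1 to compound 3 (0.29 log units; within the scatter), the first step seen at this position. On this single pair, the position accepts the methyl with exposure still within the scatter of compound 1, so the change cannot be called a real shift in either direction. Nothing measured here bears on the reason for this result.

On these data alone, whether an ethyl group, a methoxy group or an amine at this same position would stay within that scatter remains open. Also open, as far as these compounds go, is whether the methyl would give a similar step on the core of compound 2, since a single pair cannot show how far this step carries over to another core.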